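Swapping Trifluoromethoxy for Cyano on a Cell-Growth Inhibitor

This account rests on a few compounds, and the source may have more. Where it says the series, first, only, none or still open, it means among the compounds named here.

Of the compounds shown here, three have been tested in a functional assay on DU-145 cells (Homo sapiens) for antiproliferative activity, read by propidium iodide staining, with a stated time of 96 h (on this read-out higher numbers stand for weaker inhibition and lower numbers for stronger inhibition), and a fourth awaits measurement. Compound 1 `CC(O)(COc1ccc(OC(F)(F)F)cc1)C(=O)Nc1ccc(S(F)(F)(F)(F)F)cc1` gives 24800 nM in this assay. Compound 2 `CC(O)(COc1ccc(C#N)cc1)C(=O)Nc1ccc(S(F)(F)(F)(F)F)cc1` differs from it by one change, (cyano in place of trifluoromethoxy on an aromatic carbon), and in this assay compound 2 gives 32200 nM; this change made a 1.3-fold higher number from compound 1 to compound 2 (0.11 log units; within the scatter). Compound 3 `CC(O)(COc1ccc(OC(F)(F)F)cc1)C(=O)Nc1cccc(S(F)(F)(F)(F)F)c1` is built from the same atoms as compound 1, joined differently, and the difference between the two cores is not broken down here. In this assay compound 3 gives 19100 nM. The three values lie within the usual scatter of one another, so no one of them can be called stronger or weaker than the others.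

Compound 4 `CC(O)(COc1ccc(C#N)cc1)C(=O)Nc1cccc(S(F)(F)(F)(F)F)c1` carries the same change on the core of compound 3 as compound 2 carries on the core of compound 1: cyano in place of trifluoromethoxy on an aromatic carbon. The surroundings of the change are described in identical words for both pairs, so it is the same change seen twice. For the measured compounds named here, because the only measured example of it gave a 1.3-fold higher number from compound 1 to compound 2 (0.11 log units; within the scatter), a step of similar size, within the scatter, is expected on the core of compound 3 as well. The expected step is a 1.3-fold higher number from compound 3 to compound 4 (0.12 log units; within the scatter). Compound 4 is therefore estimated to give about 25000 nM in this assay, most likely between 12000 nM and 50000 nM.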

Compound 4, half-maximal inhibitory concentration: 42600 nM
Estimate against measurement, compound 4: 1.7-fold (0.23 log units) below, and the stated range covers the measured number.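

On the core of compound 3, putting cyano in place of trifluoromethoxy gave a 2.2-fold higher number from compound 3 to compound 4 (0.35 log units; beyond the scatter) in this assay, a modest weakening of the inhibition. Set beside the same change on the core of compound 1, the two steps cannot be told apart: the same change on two cores in this assay, a 1.3-fold higher number (0.11 log units; within the scatter) from compound 1 to compound 2 and a 2.2-fold higher number (0.35 log units; beyond the scatter) from compound 3 to compound 4, 1.7-fold (0.23 log units) apart, within the scatter of two such steps. So the change carried over between these two cores with no measurable difference in its effect, but two pairs do not show that it would carry to other cores, and they do not explain why only one of the two steps rises clear of the scatter.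

The compounds shown place only trifluoromethoxy and cyano on this aromatic carbon, so they cannot tell how a smaller or quite different group there, such as a fluorine atom, an amine or a carboxylic acid, would behave in this assay. They also leave open what would happen if the methyl group on the carbon that carries the hydroxyl were replaced by a longer chain, since every compound here shares that part of the structure.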